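Extending the chain: a fluorinated tail rebuilt

The compounds below may be only part of what the source reports. "The series", "measured", "known", "first", "only" and "open" are said of these compounds alone.

Measured so far in a functional assay on cells (Lymphocyte, Homo sapiens); on this read-out higher numbers stand for weaker inhibition and lower numbers for stronger inhibition: compound 1 `Nc1nc(N2CCN(C(=O)COc3ccc(Cl)cc3)CC2)c2nc(CCc3ccc(F)cc3)sc2n1` gives 4400 nM; compound 2 `Nc1nc(N2CCN(C(=O)COc3ccc(Cl)cc3)CC2)c2nc(CCOc3ccc(F)cc3)sc2n1` gives 3540 nM.

Compound 2 and compound 1 lie within the scatter of each other, the step being a 1.2-fold lower number from compound 1 to compound 2 (0.09 log units; within the scatter). Compound 3 `Nc1nc(N2CCN(C(=O)COc3ccc(Cl)cc3)CC2)c2nc(CCCc3ccc(F)cc3)sc2n1` differs from compound 2 by 4-fluorobenzyl in place of 4-fluorophenoxy on a saturated chain carbon, two bonds along the chain from an aromatic carbon. Among the compounds with values here, only the step of a 1.2-fold lower number from compound 1 to compound 2 (0.09 log units; within the scatter) bears on this, and it swapped the same two kinds of group at the same place without a change beyond the scatter. For compound 3 the estimated step is therefore a 1.1-fold higher number from compound 2 to compound 3 (0.03 log units; within the scatter), and compound 3 is expected to give about 3800 nM, between 1800 nM and 8000 nM.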

Compound 3, half-maximal inhibitory concentration: 960 nM
Beside the measured number, compound 3's estimate is 4.0-fold (0.60 log units) above it; measured number below the stated range.
By their numbers in this assay, from the lowest: compound 3; then compounds 2 and 1 (each within the scatter of the next).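

In this assay this position does respond to the tail: 3-(4-fluorophenyl)propyl gives a 3.7-fold lower number from compound 2 to compound 3 (0.57 log units; beyond the scatter) and also a 4.6-fold lower number from compound 1 to compound 3 (0.66 log units; beyond the scatter) while the earlier step stayed within the scatter. Compound 2 and compound 3 differ only in a chain oxygen exchanged for a carbon, so this one exchange is enough to shift the number here. Nothing available explains the difference.

The compounds shown leave open whether a longer chain would lower the number further. They also leave open whether an amine in the chain would behave like the oxygen or like the carbon.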